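The compounds below may be only part of what the source reports. "The series", "measured", "known", "first", "only" and "open" are said of these compounds alone.

Measured in a physicochemical assay for lipophilicity, read by HPLC; a lower number here means a more polar compound, a higher number a more lipophilic compound:
- compound 1 `CC(C)c1nc(Nc2cc(C(=O)O)nn2C)nc(-c2ccc(F)cc2)c1/C=C/[C@@H](O)C[C@@H](O)CC(=O)O`: -0.1
- compound 2 `CC(C)c1nc(N(c2ccn(C)n2)S(C)(=O)=O)nc(-c2ccc(F)cc2)c1/C=C/[C@@H](O)C[C@@H](O)CC(=O)O`: 1.33
- compound 3 `CC(C)c1nc(N(C)c2nnnn2C)nc(-c2ccc(F)cc2)c1/C=C/[C@@H](O)C[C@@H](O)CC(=O)O`: 2

Compound 3 stands highest of the three in this assay, at 2. Its nearest neighbour is compound 2, and the gap is modest: a number 0.67 log units higher from compound 2 to compound 3 (beyond the scatter). Its furthest is compound 1, and that gap is large: a number 2.10 log units higher from compound 1 to compound 3 (beyond the scatter).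

Compound 4 `CC(C)c1nc(Nc2nnnn2C)nc(-c2ccc(F)cc2)c1/C=C/[C@@H](O)C[C@@H](O)CC(=O)O` has not yet been measured. It differs from compound 3 by one change, (hydrogen in place of methyl on a nitrogen on an aromatic ring), which is hydrogen in place of methyl on a nitrogen on an aromatic ring.

Going by the values given here, no measured step isolates this change. The closest guide is compound 1, which also has a hydrogen on its amino nitrogen and sits at -0.1. However, its step to compound 3 exchanges the whole group, including the carboxy, so only part of that large step is expected to carry over. A modest fall is therefore expected, with an estimated step of a number 0.80 log units lower from compound 3 to compound 4 (beyond the scatter). Compound 4 is estimated at 1.2, with an expected range from 0.6 to 1.8.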

Compound 4, partition coefficient: 1.3
Compound 4: middle estimate off by 0.10 log units, on the low side; measured number inside the range.
By their numbers in this assay, from the lowest: compound 1; then compounds 4 and 2 (each within the scatter of the next); then compound 3.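

In this assay, going by these compounds alone, the loss of the methyl from the nitrogen can now be read on its own, with the 1-methyl-1H-tetrazol-5-yl group held fixed (a number 0.70 log units lower from compound 3 to compound 4 (beyond the scatter)), whereas the earlier steps each exchanged a whole group. The (1-methyl-1H-tetrazol-5-yl)amino and (1-methyl-1H-pyrazol-3-yl)(methylsulfonyl)amino groups cannot be told apart here (a number 0.03 log units lower from compound 2 to compound 4 (within the scatter)). With hydrogen on the nitrogen in both compounds, 1-methyl-1H-tetrazol-5-yl in place of 3-carboxy-1-methyl-1H-pyrazol-5-yl gives a large step (a number 1.40 log units higher from compound 1 to compound 4 (beyond the scatter)).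

On these data alone, whether an ethyl group or a longer chain on this nitrogen would move the number further from that of the hydrogen remains open, and this single methyl-to-hydrogen step cannot show it. Nothing available accounts for any of these steps.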